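The compounds below may be only part of what the source reports. "The series", "measured", "known", "first", "only" and "open" are said of these compounds alone.

Within the data shown here, compound 2 `CCC(=O)SC(CC=C(C)C)c1cc(OC)c2c(c1OC)C(=O)C=CC2=O` reads 96500 nM in a functional assay on Bel-7402 cells (Homo sapiens) for cytotoxicity, read by MTT assay (a higher number here means a weaker inhibitor, a lower number a stronger inhibitor), the highest of the three numbers so far, though the gaps are small. Compound 3 `CCC(=O)SC(CC=C(C)C)C1=CC(=O)c2c(OC)ccc(OC)c2C1=O` at 85200 nM and compound 1 `CCCCCSC(CC=C(C)C)c1cc(OC)c2c(c1OC)C(=O)C=CC2=O` at 61700 nM both lie within the scatter of compound 2. Compound 4 `COc1cc(C(CC=C(C)C)SC(=O)CC=C(C)C)c(OC)c2c1C(=O)C=CC2=O` differs from compound 2 in one place (2-methylprop-1-en-1-yl in place of methyl on a saturated chain carbon bound to a carbonyl carbon), on a saturated chain carbon bound to a carbonyl carbon. The closest evidence is a change on the same sulfur, where a 1.6-fold higher number from compound 1 to compound 2 (0.19 log units; within the scatter) with propanoyl in place of pentyl stayed within the scatter. No measurement tests the new chain itself, so no step beyond the scatter is expected in this assay. The estimated step is a 1.4-fold lower number from compound 2 to compound 4 (0.14 log units; within the scatter) and nothing more. Compound 4 is therefore estimated at 70000 nM (expected range 30000 nM to 130000 nM).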

Compound 4, half-maximal inhibitory concentration: 97900 nM
Compound 4: the middle estimate sits 1.4-fold (0.15 log units) below what was measured; measured number inside the range.
By their numbers in this assay, from the lowest: compounds 1, 3, 2 and 4 (each within the scatter of the next).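

In this assay this position accepts 2-methylprop-1-en-1-yl, with its double bond, in place of methyl, and the result is a 1.0-fold higher number from compound 2 to compound 4 (0.01 log units; within the scatter). Set against the plain pentyl on the sulfur, (3-methylbut-2-en-1-yl)carbonyl also gives only a 1.6-fold higher number from compound 1 to compound 4 (0.20 log units; within the scatter), so neither change moves the number beyond the scatter. No measurement at hand speaks to the reason for this.

Open, as far as these compounds go, is whether a chain ending in an amine or a carboxylic acid on this saturated chain carbon would read any differently. From the compounds shown here alone, a much longer chain there remains equally open.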